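The source may report more compounds than this note shows. Statements on the series, on what has been measured and on what is new or still open speak of the compounds shown alone.

For the measured compounds named here, in an ADME assay on MRC5 cells (Homo sapiens) for cytotoxicity, read by fluorescence and resazurin assay, with a stated time of 3 days (on this read-out lower numbers stand for an effect already at smaller amounts and higher numbers for an effect only at larger amounts of compound), compound 2 `O=C1C=CC(O)(c2cc3ccccc3n2S(=O)(=O)c2ccccc2)C=C1` gives 110 nM, the higher of the only two true numbers in the set. Compound 3 `O=C1C=CC(O)(c2cc3cnccc3n2S(=O)(=O)c2ccccc2)C=C1` gives 41 nM, a lower number, and the gap between the two lies beyond the usual scatter. Compound 1 `CC(=O)OC[C@H]1O[C@@H](n2cc(C3(O)C=CC(=O)C=C3)nn2)[C@H](OC(C)=O)[C@@H](OC(C)=O)[C@H]1OC(C)=O` reads > 50000 nM in this assay, and this is a limit of the assay, not a number.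

Compound 4 `CN1CCN(CCCc2ccc(S(=O)(=O)n3c(C4(O)C=CC(=O)C=C4)cc4ccccc43)cc2)CC1` is the next to be examined. It is compound 2 with 3-(4-methylpiperazin-1-yl)propyl in place of hydrogen on an aromatic carbon of a six-membered aromatic ring of carbon only, para to a large group (3-(4-methylpiperazin-1-yl)propyl in place of hydrogen on an aromatic carbon). Going by the values given here, no measured pair shows what such an addition does in this assay, so the expectation rests on little. The two numbers at hand, 110 nM for compound 2 and 41 nM for compound 3, lie fairly close together, and the new group leaves the shared core of compound 2 in place. A modest step towards a higher number is therefore expected, possibly no larger than the scatter. The expected change is a 1.5-fold higher number from compound 2 to compound 4 (0.16 log units; within the scatter). For compound 4 the estimated value is 160 nM, with an expected range from 40 nM to 650 nM.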

Compound 4, half-maximal effective concentration: 50 nM
The estimate for compound 4 lay 3.2-fold (0.51 log units) above the measured number; the range from low to high includes it.
By their numbers in this assay, from the lowest: compounds 3 and 4 (each within the scatter of the next); then compound 2. At a limit, above all of these: compound 1.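

For the compounds shown here, until now, no measured pair showed what a change on this ring does in this assay; compound 4 supplies the first, with 3-(4-methylpiperazin-1-yl)propyl in place of hydrogen on an aromatic carbon of a six-membered aromatic ring of carbon only, para to a large group, giving a 2.2-fold lower number from compound 2 to compound 4 (0.34 log units; beyond the scatter). The step is modest, but it lies beyond the scatter and it runs towards a lower number, so this position takes on a substantial addition, with its six-membered non-aromatic ring with 2 hetero atoms, while the effect appears at smaller amounts of compound, not larger ones. Going by these compounds alone, nothing among the measurements given here accounts for the step, and the single pair shows only its size and direction.

From the compounds shown here alone, it remains open whether the step belongs to the piperazine ring, to the propyl chain or to the terminal amine, which a plain propyl group, a shorter chain ending in the same ring or a morpholine at this carbon would help to separate. Going by these compounds, it is also open whether a carboxylic acid on a similar chain at this carbon would move the number the same way, or whether the same addition would do so on compound 3.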